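The source may report more compounds than this note shows. Statements on the series, on what has been measured and on what is new or still open speak of the compounds shown alone.

Compound 1: `CCCc1nc(C)c2c(-c3ccccc3)nnc(O)n12` — in a functional assay for inhibition, with Homo sapiens as the target (on this read-out lower numbers stand for stronger inhibition and higher numbers for weaker inhibition), compound 1 gives > 48000 nM.
Compound 2: `CCCc1nc(C)c2c(C3CC3)nnc(O)n12` — in this assay compound 2 gives > 48000 nM.

The value of compound 1 is a limit of the assay, not a measured number. The value of compound 2 is likewise only a limit. Going by the values given here, both values sit at the limit of > 48000 nM in this assay, at which 2 of the 2 values shown sit, so the single measured step, a step that the two limits leave unreadable from compound 1 to compound 2, cannot be given a size; all that is known about compound 2 is that its inhibition is too weak to register.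

Compound 3, `CCCc1nc(C)c2c(CC)nnc(O)n12`, is not yet measured. It differs from compound 2 in one place: ethyl in place of cyclopropyl on an aromatic carbon. Among the compounds with values here, the only step on record, a step that the two limits leave unreadable from compound 1 to compound 2, swaps a different ring-bearing group at the same position and is itself unreadable, so it offers no direction and no size. With compound 2 already outside the measurable range, a small change from one short carbon group to another is expected to leave compound 3 in the same place, and the step that the limit leaves unreadable from compound 2 to compound 3 is expected to be none beyond the scatter. Compound 3 is therefore estimated at 60000 nM, within a range from 20000 nM to 200000 nM, most likely reported again as a limit.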

Compound 3, half-maximal inhibitory concentration: 15600 nM
Compound 3: the middle estimate sits 3.8-fold (0.59 log units) above what was measured, and the stated range ends above it.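

With ethyl on this aromatic carbon, the series gives its first true number in this assay, which shows that a change at this position can move the read-out: ethyl in place of cyclopropyl gives an at least 3.0-fold lower number from compound 2 to compound 3 (0.48 log units; beyond the scatter), and ethyl in place of phenyl gives an at least 3.0-fold lower number from compound 1 to compound 3 (0.48 log units; beyond the scatter). Both steps are minimum sizes only, since compound 1 and compound 2 each sit at a limit of the assay rather than at a number: the limit of > 48000 nM in this assay, at which 2 of the 3 values shown sit. Among these three compounds, ethyl, the only group with no ring, gives a number, while phenyl and cyclopropyl both remain at the limit.

On these data alone, how far compound 1 and compound 2 truly lie from compound 3 stays open. Also open, as far as these compounds go, is whether a methyl, a longer chain such as butyl, or an amine on this carbon would push the number lower still.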